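Removing the Side-Chain Hydroxy from a Brominated Furanone

The compounds below may be only part of what the source reports. "The series", "measured", "known", "first", "only" and "open" are said of these compounds alone.

Measured so far:
Compound 1, `CCC[C@@H](OC(C)=O)C1=C(Br)C(=C(Br)Br)OC1=O`, gives 0.5 ug/mL in a functional assay on KB cells (Homo sapiens) for cytotoxicity; a higher number here means that more compound is needed for the effect, a lower number that less compound is needed.
Compound 2, `CCC[C@@H](O)C1=C(Br)C(=C(Br)Br)OC1=O`, gives 0.6 ug/mL in this assay.

Compound 2 stands with compound 1 on the numbers shown: the only measured step, a 1.2-fold higher number from compound 1 to compound 2 (0.08 log units; within the scatter), places the two side by side, and no order between them can be read from it. Compound 3, `CCCCC1=C(Br)C(=C(Br)Br)OC1=O`, has not yet been measured. It differs from compound 2 by hydrogen in place of hydroxy on a saturated chain carbon bound to a double-bonded ring carbon and a saturated chain carbon, so the side chain becomes butyl.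

Among the measured compounds shown here, the one step that bears on this change concerns the same oxygen: acetyl to hydrogen on it gave a 1.2-fold higher number from compound 1 to compound 2 (0.08 log units; within the scatter). Taking the oxygen away altogether is a further step along the same chain, for which no measured pair exists. Given that the acetyl-for-hydrogen exchange left the number essentially unchanged, compound 3 is expected to give a step of about a 1.2-fold higher number from compound 2 to compound 3 (0.07 log units; within the scatter), without a clear direction beyond the scatter. Compound 3 is therefore estimated at 0.7 ug/mL, within a range of 0.3 ug/mL to 1.8 ug/mL in this assay.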

Compound 3, concentration for half-maximal effect: > 20 ug/mL
Compound 3 gave a limit, no number; the forecaster's own chance of this, stated with the estimate: 5%; middle value at least 28-fold (1.45 log units) from the limit.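

For compound 3 the reading in this assay is a limit and not a number: the limit of > 20 ug/mL in this assay, at which 1 of the 3 values shown sits. Going from 1-hydroxybutyl to butyl gives an at least 33-fold higher number from compound 2 to compound 3 (1.52 log units; beyond the scatter), and replacing the acetoxy with hydrogen on the same saturated chain carbon gives an at least 40-fold higher number from compound 1 to compound 3 (1.60 log units; beyond the scatter). The earlier step, a 1.2-fold higher number from compound 1 to compound 2 (0.08 log units; within the scatter), had shown only that this oxygen could carry either acetyl or hydrogen with no difference beyond the scatter, whereas these large steps show that the outcome in this assay depends on whether an oxygen is present at this position at all, at least among these three compounds.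

The compounds shown leave open whether another group on this carbon, such as an amine, a methoxy or a fluorine, would keep the number close to that of compound 2, at 0.6 ug/mL, or whether only a hydroxy or acetoxy does so. They also leave open whether a longer chain carrying the same hydroxy, or the opposite configuration at this carbon, would stay with compound 1 and compound 2 in this assay.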